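Removing a carbonyl from the outer chain of compound 2

A few compounds are considered here, and "the series" means these few. Any claim that something is new, unique, unknown or untested is made for them only; others in the source may bear on it.

Measured so far:
compound 1 `COc1cc(N)c(Cl)cc1C(=O)NC1CCN(C(=O)C2CCN(C(=O)CCCN)CC2)CC1`: 425 nM
compound 2 `COc1cc(N)c(Cl)cc1C(=O)NC1CCN(CC2CCN(C(=O)CCCN)CC2)CC1`: 3.99 nM

In an assay on striatum for inhibition of 5-hydroxytryptamine receptor 4 (Cavia porcellus), read by radioligand binding (on this read-out lower numbers stand for stronger inhibition and higher numbers for weaker inhibition), compound 2 gives the lowest of the two numbers; compound 1 sits a long way above it, well beyond the scatter. Compound 3 `COc1cc(N)c(Cl)cc1C(=O)NC1CCN(CC2CCN(CC(O)CN)CC2)CC1` has not been measured. It differs from compound 2 in one place: 3-amino-2-hydroxypropyl in place of (3-aminopropyl)carbonyl on an amine nitrogen in a ring. Within the data shown here, no measured pair shows this exact change, so the size of the step is uncertain. A small step, within the scatter or a modest gain, is expected from compound 2 to compound 3, giving a 1.3-fold lower number from compound 2 to compound 3 (0.12 log units; within the scatter). For compound 3 the estimate is 3 nM, with a range from 0.8 nM to 12 nM.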

Compound 3, half-maximal inhibitory concentration: 14.4 nM
Estimate against measurement, compound 3: 4.8-fold (0.68 log units) below; measured number above the stated range.
By their numbers in this assay, from the lowest: compound 2; then compound 3; then compound 1.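

In this assay, putting 3-amino-2-hydroxypropyl in place of (3-aminopropyl)carbonyl on this ring nitrogen gives a 3.6-fold higher number from compound 2 to compound 3 (0.56 log units; beyond the scatter). This shows that the outer chain at this position affects the read-out, with a modest step that lies beyond the scatter. The swap removes the carbonyl and adds a hydroxyl together, and nothing shown explains the step or separates those two parts. The compounds shown leave open how a plain 3-aminopropyl group, with neither carbonyl nor hydroxyl, would read at this nitrogen. They also leave open whether a carboxylic acid could stand in for the chain's terminal amine.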